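Thiocarbamate series: nitro in place of trifluoromethyl

The compounds below may be only part of what the source reports. "The series", "measured", "known", "first", "only" and "open" are said of these compounds alone.

Measured so far in a physicochemical assay for lipophilicity; on this read-out higher numbers stand for higher lipophilicity and lower numbers for lower lipophilicity:
Compound 1, `CC(=O)Nc1ccc(OC(=S)Nc2ccc(Nc3ccc(C(F)(F)F)cc3)cc2)cc1`, gives 5.32.
Compound 2, `Oc1ccc(OC(=S)Nc2ccc(Nc3ccc(C(F)(F)F)cc3)cc2)cc1`, gives 6.04.

Compound 2 holds the highest of the two numbers in this assay. Among the compounds with values here, the single step between measured compounds is a number 0.72 log units higher from compound 1 to compound 2 (beyond the scatter), hydroxy in place of acetamido on an aromatic carbon; it sets compound 2 apart from compound 1 by a modest margin that lies beyond the scatter.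

Compound 3, `O=[N+]([O-])c1ccc(Nc2ccc(NC(=S)Oc3ccc(O)cc3)cc2)cc1`, differs from compound 2 by nitro in place of trifluoromethyl on an aromatic carbon. Within the data shown here, no measured step touches the trifluoromethyl or the nitro group; the one step between compound 1 and compound 2 concerns another group on another ring, so it gives no direct guide to the size of this change. The expectation therefore rests on the structural change alone, with wide uncertainty. Compound 3 is expected to come in lower than compound 2 in this assay, by a number 1.04 log units lower from compound 2 to compound 3 (beyond the scatter), a step expected to lie beyond the scatter. For compound 3 the estimate in this assay is 5, with a range from 4.3 to 5.7.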

Compound 3, partition coefficient: 4.54
Compound 3: the middle estimate sits 0.46 log units above what was measured; measured number inside the range.
By their numbers in this assay, from the lowest: compound 3; then compound 1; then compound 2.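

In this assay, the place para to a large group proves sensitive to the group it carries: nitro in place of trifluoromethyl on an aromatic carbon gives a number 1.50 log units lower from compound 2 to compound 3 (beyond the scatter), a large step beyond the scatter. Within the data shown here, the earlier step, a number 0.72 log units higher from compound 1 to compound 2 (beyond the scatter), was modest, went the other way and concerned hydroxy and acetamido at a different place, so this is the first reading on the trifluoromethyl position, and on this read-out the exchange counts for more than the earlier one did. No evidence at hand bears on what lies behind the size of this step.

Open, going by these compounds, is how other groups at this position would stand in this assay, for instance a nitrile, an amine or a carboxylic acid, and whether any of them would fall nearer compound 2 or nearer compound 3. Also open, on these data alone, is whether nitro in place of trifluoromethyl gives a step of similar size with acetamido rather than hydroxy on the other ring, as the exchange is seen here only with hydroxy present.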